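Isopentyl ether in place of the acetate on the shared core

The compounds below may be only part of what the source reports. "The series", "measured", "known", "first", "only" and "open" are said of these compounds alone.

Compound 1 `CC(=O)Oc1ccc2oc(/C=C/[S+](C)[O-])cc(=O)c2c1` carries an acetyl on an oxygen on an aromatic ring of the shared core. In a functional assay on DLD-1 cells (Homo sapiens) for cytotoxicity, with a stated time of 48 h (a higher number here means a weaker inhibitor, a lower number a stronger inhibitor), compound 1 gives only a limit, > 10000 nM, so its true position is not known; it stands at the limit of > 10000 nM in this assay, at which 1 of the 3 values shown sits. Compound 2 `CCCCOc1ccc2oc(/C=C/[S+](C)[O-])cc(=O)c2c1` gives 4800 nM in this assay, and compound 3 `CCCCC(=O)Oc1ccc2oc(/C=C/[S+](C)[O-])cc(=O)c2c1` gives 6700 nM. The step of an at least 2.0-fold lower number from compound 1 to compound 2 (0.31 log units; beyond the scatter) is the one that bears most directly on the change to be judged, since it also exchanges the acetyl for an alkyl chain. The step of an at least 1.4-fold lower number from compound 1 to compound 3 (0.17 log units; that floor lies within the scatter) only lengthens the acyl chain, and the step of a 1.4-fold higher number from compound 2 to compound 3 (0.14 log units; within the scatter) lies within the scatter, so ether and ester of matched chain length cannot be told apart on these numbers.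

Compound 4 `CC(C)CCOc1ccc2oc(/C=C/[S+](C)[O-])cc(=O)c2c1` is not yet measured. It differs from compound 1 as follows: isopentyl in place of acetyl on an oxygen on an aromatic ring. Because compound 1 reaches only the limit > 10000 nM and the step of an at least 2.0-fold lower number from compound 1 to compound 2 (0.31 log units; beyond the scatter) went to a lower number for a butyl chain, a lower number than that limit is expected for compound 4 in this assay as well, in the same direction as an at least 2.0-fold lower number from compound 1 to compound 2 (0.31 log units; beyond the scatter) and of similar size, the estimated step being an at least 2.2-fold lower number from compound 1 to compound 4 (0.34 log units; beyond the scatter). Compound 4 is thus expected to give about 4500 nM, with a range from 1800 nM to 11000 nM.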

Compound 4, half-maximal inhibitory concentration: 4100 nM
The estimate for compound 4 lay 1.1-fold (0.04 log units) above the measured number; low and high end bracket the measured number.
By their numbers in this assay, from the lowest: compounds 4, 2 and 3 (each within the scatter of the next). At a limit, above all of these: compound 1.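

In this assay, the step of an at least 2.4-fold lower number from compound 1 to compound 4 (0.38 log units; beyond the scatter) shows that a second alkyl ether, this one branched, also gives a measured number where the acetyl compound reaches only a limit, so this result at the oxygen on the aromatic ring is not confined to the butyl chain. Branching of the chain makes no readable difference: the step of a 1.2-fold lower number from compound 2 to compound 4 (0.07 log units; within the scatter) adds one methyl and stays within the scatter, and the step of a 1.6-fold lower number from compound 3 to compound 4 (0.21 log units; within the scatter) likewise leaves the isopentyl ether and the longer ester of compound 3 unseparated. Compound 1 alone stands apart from the other three, and its position is known only as a limit: the limit of > 10000 nM in this assay, at which 1 of the 4 values shown sits.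

All the groups shown at this oxygen are short acyl or alkyl chains, so it remains open whether a longer chain such as decyl, or a benzyl group, would move the number beyond the scatter of compounds 2, 3 and 4. From the compounds shown here alone, it also remains open how a free hydroxyl at this position, or an amine at the end of the chain, would read in this assay.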